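The source may hold more compounds than are shown below. What is called first, only, known or untested is meant among the compounds shown, and "the series" means these compounds.

Measured compounds in the series:

- compound 1 `CSc1cccc(Nc2nc(-c3ccc(F)cc3)cs2)c1` – "not active" (no number reported)
- compound 2 `CSc1cccc(Nc2nc(-c3cccc(Cl)c3)cs2)c1` – 5300 nM
- compound 3 `CSc1cccc(Nc2nc(-c3nccs3)cs2)c1` – "not active" (no number reported)

In an assay on CFBE41o cells with Cystic fibrosis transmembrane conductance regulator variant F508del (Homo sapiens) as the target, with a stated time of 24 h (a lower number here means that less compound is needed, a higher number that more compound is needed for the effect), compound 2 gives 5300 nM. For compound 1 the result in this assay is reported only as "not active" (no number reported), without a number. Compound 3 stands in the same position: in this assay it is reported as "not active" (no number reported), and no half-maximal effective concentration is given. Compound 3 therefore has no number against which a step could be measured, and a second compound of the set is in the same situation.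

Compound 4 `CSc1cccc(Nc2nc(-c3cc(Cl)cs3)cs2)c1` differs from compound 3 by 4-chlorothiophen-2-yl in place of 1,3-thiazol-2-yl on an aromatic carbon. Going by the values given here, with no number for compound 3, the size and direction of the step cannot be read from the set; the only reference is that compound 2, which carries a chlorine on its aryl ring, gives 5300 nM in this assay, whereas compound 1 and compound 3 give none. Compound 4 is expected to land in the weak range, around 8000 nM, with a range of 2500 nM to 25000 nM, and a real chance that this assay reports it as not active.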

Compound 4, half-maximal effective concentration: "not active" (no number reported)
No number was reported for compound 4; no gap can be computed for the estimate.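

In this assay, going by these compounds alone, compound 3 and compound 4 both stand without a number, so no step between them can be read. The compounds shown leave open whether 4-chlorothiophen-2-yl in place of 1,3-thiazol-2-yl shifts the half-maximal effective concentration at all. No measured evidence bears on this result.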